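Chloro in place of fluoro on the benzyl arm of compound 3

The compounds below may be only part of what the source reports. "The series", "measured", "known", "first", "only" and "open" are said of these compounds alone.

Three hydroxamic acids on a shared core have been tested in an assay on isolated protein for inhibition of protein deacetylase HDAC6 (Homo sapiens), with a stated time of 60 min; on this read-out higher numbers stand for weaker inhibition and lower numbers for stronger inhibition. Compound 1 `CS(=O)(=O)c1ccc(-n2ccc3cnc(Nc4cnn(CCCCCC(=O)NO)c4)nc32)cc1` gives 10.8 nM, compound 2 `O=C(CCCCCn1cc(Nc2ncc3ccn(Cc4ccccc4Cl)c3n2)cn1)NO` gives 45 nM, and compound 3 `O=C(CCCCCn1cc(Nc2ncc3ccn(Cc4cccc(F)c4)c3n2)cn1)NO` gives 13.7 nM. Compound 3 holds the second highest of the three numbers: its nearest neighbour is compound 1, within the scatter, and its furthest is compound 2, beyond it, as a 3.3-fold lower number from compound 2 to compound 3 (0.52 log units; beyond the scatter) shows.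

Compound 4 `O=C(CCCCCn1cc(Nc2ncc3ccn(Cc4cccc(Cl)c4)c3n2)cn1)NO` differs from compound 3 by one atom: chloro in place of fluoro on an aromatic carbon. Going by the values given here, no measured step swaps chloro for fluoro at the same place. The step of a 3.3-fold lower number from compound 2 to compound 3 (0.52 log units; beyond the scatter) changes halogen and place together, so it does not isolate the halogen. The steps of a 4.2-fold higher number from compound 1 to compound 2 (0.62 log units; beyond the scatter) and a 1.3-fold higher number from compound 1 to compound 3 (0.10 log units; within the scatter) show that the group on the aromatic nitrogen can be varied with at most a modest effect in this assay. On that basis the author expects the change from fluoro to chloro to give no step beyond the scatter for compound 4, with a 1.0-fold higher number from compound 3 to compound 4 (0.01 log units; within the scatter).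

Compound 4 is therefore estimated at 14 nM, within a range from 7 nM to 30 nM.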

Compound 4, half-maximal inhibitory concentration: 34.4 nM
Beside the measured number, compound 4's estimate is 2.5-fold (0.39 log units) below it, and the stated range ends below it.
By their numbers in this assay, from the lowest: compounds 1 and 3 (each within the scatter of the next); then compounds 4 and 2 (each within the scatter of the next).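

In this assay, going by these compounds alone, the halogen on the benzyl arm can now be read on its own: with chloro in place of fluoro on an aromatic carbon as the only change, there is a 2.5-fold higher number from compound 3 to compound 4 (0.40 log units; beyond the scatter) and so a single atom at this place is enough to move the number past the scatter. With chloro kept and only its place changed, 3-chlorophenyl in place of 2-chlorophenyl gives a 1.3-fold lower number from compound 2 to compound 4 (0.12 log units; within the scatter) and thus no separation of these two chloro compounds, while 3-chlorobenzyl, unlike 3-fluorobenzyl, stands apart from the 4-(methylsulfonyl)phenyl group of compound 1, with a 3.2-fold higher number from compound 1 to compound 4 (0.50 log units; beyond the scatter) as the measure of that gap. No supporting data bear on why fluoro and chloro differ at this place.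

Going by these compounds, it remains open how bromo, methoxy or an amine would read at the same place on the benzyl arm, and how a 2-fluorobenzyl group would compare with the 2-chlorobenzyl group of compound 2. On these data alone, it is also open whether the step from fluoro to chloro would persist with a longer chain carrying the hydroxamic acid.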